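Aryl ether variation in the pyrrolidine acetic acid series

The source may hold more compounds than are shown below. What is called first, only, known or untested is meant among the compounds shown, and "the series" means these compounds.

In a functional assay on cells for agonist activity at Free fatty acid receptor 1 (Mus musculus), read by FLIPR and calcium flux, with a stated time of 100 s (on this read-out lower numbers stand for an effect already at smaller amounts and higher numbers for an effect only at larger amounts of compound), compound 1 `Cc1ccccc1COc1ccc(N2CCC[C@H]2CC(=O)O)cc1` gives 3400 nM. Compound 2 `O=C(O)C[C@@H]1CCCN1c1ccc(Oc2ccccc2F)cc1` gives 6900 nM in this assay. Compound 3 `O=C(O)C[C@@H]1CCCN1c1ccc(Oc2cccc(Cl)c2)cc1` sits only at a limit of this assay, > 16000 nM; this is the limit of > 16000 nM in this assay, at which 1 of the 3 values shown sits, so for compound 3 no number is known, only a floor. The measured steps are a 2.0-fold higher number from compound 1 to compound 2 (0.31 log units; beyond the scatter), an at least 4.7-fold higher number from compound 1 to compound 3 (0.67 log units; beyond the scatter) and an at least 2.3-fold higher number from compound 2 to compound 3 (0.36 log units; beyond the scatter): every exchange of the group on the ether oxygen moved the number, and the 3-chlorophenyl ether of compound 3 gave the highest value seen.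

Compound 4 `Cc1ccc(Oc2ccc(N3CCC[C@H]3CC(=O)O)cc2)cc1` carries 4-methylphenyl in place of 3-chlorophenyl on an oxygen on an aromatic ring. Among the compounds with values here, no measured step compares two groups on this oxygen that differ only in the ring substituent and its place, so the bearing of the three steps on this change is indirect; they show only that this position is sensitive and that compound 3 is the weak end. The expectation is that compound 4 lands near compound 2 or between compound 2 and compound 3, with the step of an at least 1.6-fold lower number from compound 3 to compound 4 (0.20 log units; that floor lies within the scatter) expected to be toward lower numbers but uncertain because compound 3 shows only > 16000 nM. Compound 4 is estimated at 10000 nM, within 3000 nM to 30000 nM.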

Compound 4, half-maximal effective concentration: > 33000 nM
Compound 4 ended at the assay's limit; the forecaster's own chance of this, stated with the estimate: 40%; at least 3.3-fold (0.51 log units) between middle value and limit.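

Compound 4 stands only at a limit in this assay, not at a number: the limit of > 33000 nM in this assay, at which 1 of the 4 values shown sits. Against the two ethers with readable values, the 4-methylphenyl group gives an at least 4.7-fold higher number from compound 2 to compound 4 (0.67 log units; beyond the scatter) and an at least 9.7-fold higher number from compound 1 to compound 4 (0.98 log units; beyond the scatter), so of the three phenyl ethers shown only compound 2, the 2-fluorophenyl ether, gives a number. Compound 3 also stands only at a limit, so its step to compound 4 cannot be read: the limit of > 16000 nM in this assay, at which 1 of the 4 values shown sits.

As far as these compounds go, whether the 3-chlorophenyl and 4-methylphenyl ethers differ at all stays open. Also open, from the compounds shown here alone, is how a 2-chlorophenyl, 2-methylphenyl or 4-methylbenzyl group on this oxygen would read, and so whether the readable values of compound 1 and compound 2 extend to close relatives of those groups.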